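A bromophenyl swap on a compound at the limit

The source may report more compounds than this note shows. Statements on the series, on what has been measured and on what is new or still open speak of the compounds shown alone.

Measured in a functional assay on SEM cells (Homo sapiens) for cytotoxicity, with a stated time of 72 h; a higher number here means that more compound is needed for the effect, a lower number that less compound is needed:
Compound 1 `C=C[C@@](C)(/C=C/c1ccc(OS(=O)(=O)C(F)(F)F)cc1)CCC=C(C)C`: > 36600 nM (a limit)
Compound 2 `C=C[C@@](C)(/C=C/c1ccc(-c2ccc(F)cc2)cc1)CCC=C(C)C`: > 36600 nM (a limit)

Compound 2 stands at a limit of the assay and not at a number, with > 36600 nM as its entry. It shares that position with compound 1, as the limit of > 36600 nM in this assay, at which 2 of the 2 values shown sit, shows. Compound 3 `C=C[C@@](C)(/C=C/c1ccc(-c2cccc(Br)c2)cc1)CCC=C(C)C` differs from compound 2 in one place, where 3-bromophenyl takes the place of 4-fluorophenyl on an aromatic carbon: 3-bromophenyl in place of 4-fluorophenyl on an aromatic carbon. Going by the values given here, the only measured step, a step that the two limits leave unreadable from compound 1 to compound 2, also changed a group on an aromatic carbon, but it offers no size to carry over. No step beyond the scatter, in either direction, is therefore expected in this assay. The estimated step is a step that the limit leaves unreadable from compound 2 to compound 3. Compound 3 is estimated at 40000 nM, with an expected range from 15000 nM to 90000 nM.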

Compound 3, half-maximal effective concentration: > 36600 nM
Compound 3: a limit, no number; the forecaster's own chance of this, stated with the estimate: 70%; the middle value does not contradict the limit.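

No step can be read between compound 1, compound 2 and compound 3, because each gives a limit and not a number: the limit of > 36600 nM in this assay, at which 3 of the 3 values shown sit. The compounds shown leave open how much of each would be needed for the effect in this assay, and whether swapping the group on the aromatic carbon changes that amount.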